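This account rests on a few compounds, and the source may have more. Where it says the series, first, only, none or still open, it means among the compounds named here.

Compound 1 `COc1ccc2c(=O)c(-c3cc(OC)c(OC)cc3OC)coc2c1` is the smallest member of the group shown here, and in a functional assay on A-375 cells (Homo sapiens) for antiproliferative activity, read by MTT assay, with a stated time of 24 h (a lower number here means a stronger inhibitor, a higher number a weaker inhibitor), compound 1 gives 2640 nM. Compound 2 `COc1cc(OC)c(-c2coc3cc(OCc4ccc([N+](=O)[O-])cc4)ccc3c2=O)cc1OC` carries a 4-nitrophenyl on the saturated chain carbon bound to an oxygen on the aromatic ring; in this assay compound 2 reaches only the limit of the assay, > 10000 nM. Compound 3 `COc1cc(OC)c(-c2coc3cc(OCc4ccccc4C(F)(F)F)ccc3c2=O)cc1OC` likewise gives only a limit in this assay, > 10000 nM, so no number is known for compound 3 itself. The two steps from compound 1, an at least 3.7-fold higher number from compound 1 to compound 2 (0.57 log units; beyond the scatter) and an at least 3.7-fold higher number from compound 1 to compound 3 (0.57 log units; beyond the scatter), both run toward weaker inhibition, while the step between the two limits, a step that the two limits leave unreadable from compound 2 to compound 3, cannot be read, because of the limit of > 10000 nM in this assay, at which 2 of the 3 values shown sit. Compound 4 `COc1cc(OC)c(-c2coc3cc(OCc4cccc(C(F)(F)F)c4)ccc3c2=O)cc1OC` differs from compound 3 only in where the trifluoromethyl sits: 3-(trifluoromethyl)phenyl in place of 2-(trifluoromethyl)phenyl on a saturated chain carbon bound to an oxygen on an aromatic ring. Going by the values given here, no measured step compares two positional isomers of this kind, so the change from compound 3 to compound 4 is expected to stay within the scatter, a step that the limit leaves unreadable from compound 3 to compound 4. Compound 4 is therefore estimated at 12000 nM, with a range from 3000 nM to 40000 nM, most likely again a limit.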

Compound 4, half-maximal inhibitory concentration: 1140 nM
Estimate against measurement, compound 4: 11-fold (1.02 log units) above, outside the stated range (below it).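

In this assay, moving the trifluoromethyl with no change in atoms proves decisive, with 3-(trifluoromethyl)phenyl in place of 2-(trifluoromethyl)phenyl giving an at least 8.7-fold lower number from compound 3 to compound 4 (0.94 log units; beyond the scatter). The same group also compares favourably with the 4-nitrophenyl, giving an at least 8.7-fold lower number from compound 2 to compound 4 (0.94 log units; beyond the scatter). Substitution on the saturated chain carbon bound to an oxygen on an aromatic ring therefore need not weaken inhibition, since compound 4 shows a 2.3-fold lower number from compound 1 to compound 4 (0.36 log units; beyond the scatter), whereas compound 2 and compound 3 both went the other way from compound 1.

From the compounds shown here alone, the true size of the two larger steps stays unknown because they rest on a limit rather than a number: the limit of > 10000 nM in this assay, at which 2 of the 4 values shown sit. Whether the gain needs the trifluoromethyl at all stays open, as an unsubstituted benzyl, a chlorobenzyl or a longer chain carrying the same phenyl could show.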